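A serine-type ester replaces a glutamate diester

The source may report more compounds than this note shows. Statements on the series, on what has been measured and on what is new or still open speak of the compounds shown alone.

Measured compounds:
compound 1, `O=C(CN(c1ncnc2c1ncn2C1CCCCO1)C1CC1)N[C@@H](CCC(=O)OCc1ccccc1)C(=O)OCc1ccccc1`, 14.1%
compound 2, `O=C(OCc1ccccc1)[C@@H]1CCCN1C(=O)CN(c1nc(Cl)nc2[nH]cnc12)C1CC1`, 31.1%
compound 3, `NC(=O)C[C@H](NC(=O)CN(c1nc(Cl)nc2[nH]cnc12)C1CC1)C(=O)O`, 7.51%

In a functional assay on the whole organism (Tail, strain ICR) with Mus musculus as the target, in the tail flick test, with a stated time of 150 min, at a dose of 25 umol/kg by the oral route (on this read-out higher numbers stand for a stronger effect at the one dose given and lower numbers for a weaker effect), compound 1 gives 14.1%. Among the three numbers recorded this is the second highest. Its nearest neighbour is compound 3, whose value of 7.51% lies within the usual scatter of compound 1, so no order can be read between those two. Compound 2, with 31.1%, stands beyond the scatter above compound 1; the structures of compound 2 and compound 3 differ from compound 1 in more than one place, and only their two values are known.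

Compound 4, `O=C(CN(c1ncnc2c1ncn2C1CCCCO1)C1CC1)N[C@@H](CO)C(=O)OCc1ccccc1`, has not yet been measured. It differs from compound 1 by hydroxy in place of (benzyloxycarbonyl)methyl on a saturated chain carbon, two bonds along the chain from an amide-type nitrogen and a carbonyl carbon. Nothing measured here isolates this change on its own, so the step in this assay is not known from the data.

Compound 4 is expected to give 10%, with a range from 2% to 25%. The expected step of a number 4.1 percentage points lower from compound 1 to compound 4 (within the scatter) is small and, at most, lies at the edge of the scatter, leaning slightly downward because compound 3 gives 7.51%.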

Compound 4, a percentage reported as activity, at one dose (the size of the read-out at that dose, not a potency): 18.3%
Beside the measured number, compound 4's estimate is 8.3 percentage points below it; measured number inside the range.
By their numbers in this assay, from the lowest: compounds 3, 1 and 4 (each within the scatter of the next, the first and the last beyond it); then compound 2.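

In this assay, putting hydroxy in place of (benzyloxycarbonyl)methyl on a saturated chain carbon, two bonds along the chain from an amide-type nitrogen and a carbonyl carbon, gives a number 4.2 percentage points higher from compound 1 to compound 4 (within the scatter). Among these compounds, this is the first reading of this position on its own: the group that leaves holds 11 heavy atoms and a six-membered aromatic ring of carbon only, the group that enters holds 1 heavy atom, and at this one dose and time the read-out does not separate the two compounds. Nothing on hand accounts for this outcome, so the step stands as an observation only.

On these data alone, whether the same holds for an amine or a carboxylic acid at this position, or for a longer chain ending in hydroxy, remains open, as does any difference between compound 1 and compound 4 at other doses or times. Compound 2 and compound 3 differ from compound 4 in more than one place, so steps to them cannot be read, and the part played by the benzyl ester that compound 1 and compound 4 share is also unknown.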